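The source may hold more compounds than are shown below. What is called first, only, known or untested is meant among the compounds shown, and "the series" means these compounds.

- compound 1 (`CC1=NN(C(=O)COc2ccc(Cl)cc2)C(c2ccccc2O)C1`) gives "not active" (no number reported)
- compound 2 (`CC1=NN(C(=O)COc2ccc(Cl)cc2)C(c2cc(Br)ccc2O)C1`) gives "not active" (no number reported)
- compound 3 (`CC1=NN(S(=O)(=O)c2ccc(C)cc2)C(c2cc(Br)ccc2O)C1`) gives 20800 nM

In a functional assay on HepG2 cells (Homo sapiens) for cytotoxicity, read by MTT assay, with a stated time of 48 h (a higher number here means a weaker inhibitor, a lower number a stronger inhibitor), compound 1 stands without a single number. It reads "not active" (no number reported) in this test, and compound 2 shares that reading with "not active" (no number reported) as its entry. Only compound 3 yields a number, with 20800 nM as its result.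

Compound 4 (`CC1=NN(C(=O)CN2CCN(C)CC2)C(c2ccccc2O)C1`) keeps the core of compound 1 and differs from it in one place. The change is 4-methylpiperazin-1-yl in place of 4-chlorophenoxy on a saturated chain carbon bound to a carbonyl carbon and it puts 4-methylpiperazin-1-yl in place of 4-chlorophenoxy on a saturated chain carbon bound to a carbonyl carbon.

Within the data shown here, no measured pair shows this change, so the size of the step in this assay cannot be read from the data. A modest move toward stronger inhibition is expected, from no number to a weak one, though another reading without a number would be no surprise. Compound 3 at 20800 nM gives the only scale for that expectation. For compound 4 the estimated value is 40000 nM with 15000 nM to 100000 nM as the expected range.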

Compound 4, half-maximal inhibitory concentration: "not active" (no number reported)
For compound 4 the study gives words and no number; there is nothing to compare the estimate with.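

In this assay, among these compounds, compound 1 gives "not active" (no number reported) and compound 4 gives "not active" (no number reported), so no step between them can be read. The compounds shown leave open how far 4-methylpiperazin-1-yl in place of 4-chlorophenoxy shifts inhibition. No evidence bears on this result.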